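The source may report more compounds than this note shows. Statements on the series, on what has been measured and on what is new or still open speak of the compounds shown alone.

Compound 1 `O=C1C(=O)N(CCCCCn2cc(COc3cc(=O)oc4ccccc34)nn2)c2ccc(F)cc21` and compound 2 `O=C1C(=O)N(CCCCCn2cc(COc3cc(=O)oc4ccccc34)nn2)c2ccc(I)cc21` share one core; compound 2 carries iodo in place of fluoro on an aromatic carbon. In a functional assay on THP-1 cells (Homo sapiens) for inhibition, read by sulforhodamine B assay, with a stated time of 48 h, tested at 50 uM (a lower number here means less inhibition of growth, a higher number more inhibition of growth at the concentration tested), compound 1 gives 63%. Compound 2 gives 45% in this assay, so a number 18 percentage points lower from compound 1 to compound 2 (beyond the scatter). Compound 3 `O=C1C(=O)N(CCCCn2cc(COc3cc(=O)oc4ccccc34)nn2)c2ccc(F)cc21` stands on a different core; the difference between the two cores is not broken down here. In this assay compound 3 gives 77%, the highest of the three numbers, beyond the scatter from both others. Compound 4 `O=C1C(=O)N(CCCCn2cc(COc3cc(=O)oc4ccccc34)nn2)c2ccc(I)cc21` is not yet measured and carries on the core of compound 3 the same change seen once before: iodo in place of fluoro on an aromatic carbon. Among the measured compounds shown here, only one earlier instance exists, a number 18 percentage points lower from compound 1 to compound 2 (beyond the scatter), and a step of about that size is expected again, since nothing in the data separates the two cores in this respect. For compound 4 the expected step is a number 18 percentage points lower from compound 3 to compound 4 (beyond the scatter). Compound 4 is therefore estimated at 59%, most likely between 45% and 72%.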

Compound 4, percent growth inhibition at one concentration: 59%
The estimate for compound 4 equals the measured number at the digits printed; the range from low to high includes it.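

In this assay, iodo in place of fluoro on an aromatic carbon gives a number 18 percentage points lower from compound 3 to compound 4 (beyond the scatter), so on these two cores the change carries over with no difference in step size: the same change on two cores in this assay, a number 18 percentage points lower (beyond the scatter) from compound 1 to compound 2 and a number 18 percentage points lower (beyond the scatter) from compound 3 to compound 4, 0 percentage points apart, within the scatter of two such steps. Among the compounds shown here, the agreement rests on only two matched pairs, with a single exchange of groups, and on growth inhibition read at a single concentration. It does not show that the step holds on any further core, or that other changes carry across these two cores in the same way.

Still open, on these data alone, is whether chloro or bromo on the same aromatic carbon gives a step in line with iodo. Also open, as far as these compounds go, is whether a methoxy group or a nitrile there, or a shorter or longer chain, leaves the step unchanged.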